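Fluoro for methyl on the anilide ring

The source may hold more compounds than are shown below. What is called first, only, known or untested is meant among the compounds shown, and "the series" means these compounds.

Compound 1 `Cc1cccc(NC(=O)c2cccc(/C=C3\CC(=O)N(c4ccccc4)C3=O)c2)c1` was tested in an ADME assay on NCM460 cells (Homo sapiens) for cytotoxicity, read by MTT assay, with a stated time of 72 h (on this read-out lower numbers stand for stronger inhibition and higher numbers for weaker inhibition), and gave > 100000 nM, which is a limit of the assay rather than a number. Compound 2 `CCCCCN1C(=O)C/C(=C\c2cccc(C(=O)Nc3cccc(CC)c3)c2)C1=O` in this assay gave > 100000 nM, also a limit. Compound 3 `Cc1ccc(N2C(=O)C/C(=C\c3cccc(C(=O)Nc4ccc(Cl)cc4)c3)C2=O)cc1` in this assay gave > 100000 nM, again a limit. All that can be said of compound 1 is that it sits at the same limit as the two other measured compounds; no order among the three follows from these values. Among the measured compounds shown here, the one piece of evidence on the series is the limit of > 100000 nM in this assay, at which 3 of the 3 values shown sit.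

Compound 4 `O=C(Nc1cccc(F)c1)c1cccc(/C=C2\CC(=O)N(c3ccccc3)C2=O)c1` has not yet been measured in this assay. It differs from compound 1 in one place: fluoro in place of methyl on an aromatic carbon. For the measured compounds named here, no step between two measured compounds is available to calibrate this change, so the expectation rests on the fact that every measured compound sits at the limit (the limit of > 100000 nM in this assay, at which 3 of the 3 values shown sit). The expected step is a number no higher from compound 1 to compound 4 (the limit leaves the size open), which is no change beyond the scatter. Compound 4 is therefore estimated at 100000 nM in this assay, within a range of 50000 nM to 200000 nM, and most likely the assay will again report only a limit.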

Compound 4, half-maximal inhibitory concentration: > 100000 nM
Compound 4 gave a limit, no number; the forecaster's own chance of this, stated with the estimate: 85%; the middle value sits exactly at the limit.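

In this assay compound 4 gives > 100000 nM as a limit and not a number. Compound 1 also stands at a limit, so the step from methyl to fluoro between compound 1 and compound 4 cannot be read. The compounds shown leave open whether any change to the shared core gives a measurable value: the limit of > 100000 nM in this assay, at which 4 of the 4 values shown sit.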